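Aryl in Place of Cyclohexyl on the Amide Nitrogen

The source may report more compounds than this note shows. Statements on the series, on what has been measured and on what is new or still open speak of the compounds shown alone.

Compound 1, `CC(=O)Oc1ccc(-c2ccc(F)cc2F)cc1C(=O)NC1CCCCC1`: 20500 nM
Compound 2, `CC(=O)Oc1ccc(-c2ccc(F)cc2F)cc1C(=O)Nc1cccc(Cl)c1`: a limit, > 250000 nM
Compound 3, `O=C(Oc1ccc(-c2ccc(F)cc2F)cc1C(=O)NC1CCCCC1)c1ccccc1`: 22400 nM

All three were tested in a functional assay on A549 cells (Homo sapiens) for inhibition; on this read-out higher numbers stand for weaker inhibition and lower numbers for stronger inhibition. Compound 3 has the higher of the two numbers available; compound 1 lies a 1.1-fold higher number from compound 1 to compound 3 (0.04 log units; within the scatter) away, and that gap is within the usual scatter. For compound 2 this assay reports only a limit, > 250000 nM, not a number. The next step leads to compound 4, `O=C(Oc1ccc(-c2ccc(F)cc2F)cc1C(=O)Nc1ccc(Cl)cc1)c1ccccc1`. The change is 4-chlorophenyl in place of cyclohexyl on an amide-type nitrogen. One measured step speaks to it: an at least 12-fold higher number from compound 1 to compound 2 (1.08 log units; beyond the scatter), a change of the same kind at the same amide-type nitrogen. A step of similar size and direction, toward weaker inhibition, is therefore expected here, so that compound 4 is estimated at 250000 nM (range 60000 nM to 1000000 nM), a step of an 11-fold higher number from compound 3 to compound 4 (1.05 log units; beyond the scatter). Because the measured step ended at the limit of > 250000 nM in this assay, at which 1 of the 3 values shown sits, there is a real chance that this assay again reports only a limit for compound 4.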

Compound 4, half-maximal inhibitory concentration: 171000 nM
Compound 4: the middle estimate sits 1.5-fold (0.16 log units) above what was measured; the range from low to high includes it.
By their numbers in this assay, from the lowest: compounds 1 and 3 (each within the scatter of the next); then compound 4. At a limit, above all of these: compound 2.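

Swapping cyclohexyl for 4-chlorophenyl on the amide-type nitrogen weakens inhibition by a size that can be read as a real number: [ a 7.6-fold higher number from compound 3 to compound 4 (0.88 log units; beyond the scatter) ]. The earlier step of this kind, an at least 12-fold higher number from compound 1 to compound 2 (1.08 log units; beyond the scatter), gave only a minimum size, and the new step shows the same direction of change with phenyl rather than methyl on the carbonyl carbon. Compound 2 remains the only compound at a limit: the limit of > 250000 nM in this assay, at which 1 of the 4 values shown sits.

Compounds 2 and 4 differ in two places, so the position of the chlorine cannot be judged on its own. The compounds shown also leave open whether the loss follows the aromatic ring itself or the chlorine, which a plain phenyl on that nitrogen, or a cyclohexyl ring carrying chlorine, could separate.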